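Dimethylamino in place of 4-methylpiperazin-1-yl: an expected tolerance

This account rests on a few compounds, and the source may have more. Where it says the series, first, only, none or still open, it means among the compounds named here.

In a toxicity assay on Huh-7.5 cells (Homo sapiens) for inhibition, read by MTT assay, with a stated time of 96 h (a lower number here means that less compound is tolerated, a higher number that more compound is tolerated), compound 1 (`CCOc1ccc(C(=O)Nc2ccc(OC)cc2)cc1NC(=O)CC`) gives 73200 nM and compound 2 (`CCC(=O)Nc1cc(C(=O)Nc2ccc(OC)cc2)ccc1OCCCN1CCN(C)CC1`) gives 127000 nM, two values within the scatter of each other. Compound 3 (`CCC(=O)Nc1cc(C(=O)Nc2ccc(OC)cc2)ccc1OCCCN(C)C`) differs from compound 2 by dimethylamino in place of 4-methylpiperazin-1-yl on a saturated chain carbon, three bonds along the chain from an oxygen on an aromatic ring, with dimethylamino in place of 4-methylpiperazin-1-yl on a saturated chain carbon, three bonds along the chain from an oxygen on an aromatic ring. Within the data shown here, the only measured step that bears on this is a 1.7-fold higher number from compound 1 to compound 2 (0.24 log units; within the scatter), which installed the group now leaving. No step beyond the scatter is therefore expected, and the estimated step is a 1.3-fold lower number from compound 2 to compound 3 (0.10 log units; within the scatter) in this assay at most modest. Compound 3 is expected at 100000 nM, with 50000 nM to 200000 nM as the estimated range.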

Compound 3, half-maximal cytotoxic concentration: 154000 nM
Compound 3: middle estimate off by 1.5-fold (0.19 log units), on the low side; measured number inside the range.
By their numbers in this assay, from the lowest: compounds 1, 2 and 3 (each within the scatter of the next, the first and the last beyond it).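

In this assay the step from 4-methylpiperazin-1-yl to dimethylamino at this position is a 1.2-fold higher number from compound 2 to compound 3 (0.08 log units; within the scatter) and so shows that the six-membered ring can be given up without a step beyond the scatter. Among these compounds, with (dimethylamino)methyl in place of hydrogen, two bonds along the chain from an oxygen on an aromatic ring, the result is (a 2.1-fold higher number from compound 1 to compound 3 (0.32 log units; beyond the scatter)), the only step here beyond the scatter, and a modest one. Nothing measured accounts for either step.

On these data alone, whether a morpholine ring or a primary amine in place of dimethylamino, or a longer chain, would give similar numbers remains open.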